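Halogenated aryl piperazines on a xanthine-like core

This account rests on a few compounds, and the source may have more. Where it says the series, first, only, none or still open, it means among the compounds named here.

Measured compounds:
- compound 1, `CCCn1c(=O)[nH]c2nc(-c3ccc(S(=O)(=O)N4CCN(c5ccccc5Br)CC4)cc3)[nH]c2c1=O`: 0.137 nM
- compound 2, `CCCn1c(=O)[nH]c2nc(-c3ccc(S(=O)(=O)N4CCN(c5cccc(F)c5)CC4)cc3)[nH]c2c1=O`: 0.632 nM
- compound 3, `CCCn1c(=O)[nH]c2nc(-c3ccc(S(=O)(=O)N4CCN(C(C)c5ccccc5)CC4)cc3)[nH]c2c1=O`: 8.34 nM

All three share the same core and differ only in the group on an amine nitrogen in a ring. In an assay on CHO cells for displacement of a labelled ligand from adenosine receptor A2b (Homo sapiens), read by scintillation counting, with a stated time of 75 min, in the presence of a further agent that is not named here (on this read-out lower numbers stand for stronger inhibition and higher numbers for weaker inhibition), compound 3 gives the highest number of the three: the step of a 61-fold higher number from compound 1 to compound 3 (1.78 log units; beyond the scatter) is large, and so is a 13-fold higher number from compound 2 to compound 3 (1.12 log units; beyond the scatter), so compound 3 is clearly the weakest binder shown.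

Compound 4, `CCCn1c(=O)[nH]c2nc(-c3ccc(S(=O)(=O)N4CCN(c5ccccc5Cl)CC4)cc3)[nH]c2c1=O`, has not been measured. It differs from compound 3 by 2-chlorophenyl in place of 1-phenylethyl on an amine nitrogen in a ring. The closest comparison is compound 1, which carries 2-bromophenyl at the same place, and the step of a 61-fold higher number from compound 1 to compound 3 (1.78 log units; beyond the scatter) shows how much the number rose when an aryl group with a halogen gave way to 1-phenylethyl. A 2-chlorophenyl group is close to a 2-bromophenyl group, so reversing that change is expected to bring the number back down by a large margin in this assay, roughly a 42-fold lower number from compound 3 to compound 4 (1.62 log units; beyond the scatter), though with no direct measurement of chlorine against bromine a somewhat smaller drop cannot be excluded. Compound 4 is therefore expected to give about 0.2 nM, within a range from 0.07 nM to 0.6 nM.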

Compound 4, inhibition constant: 0.403 nM
Compound 4: middle estimate off by 2.0-fold (0.30 log units), on the low side; low and high end bracket the measured number.
By their numbers in this assay, from the lowest: compound 1; then compounds 4 and 2 (each within the scatter of the next); then compound 3.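

In this assay, within the data shown here, the change of bromo to chloro on the same aromatic carbon gives the first comparison of two halogens at one spot on this group, and the halogen does matter (a 2.9-fold higher number from compound 1 to compound 4 (0.47 log units; beyond the scatter)), though the step is smaller than the one from replacing the whole group (a 21-fold lower number from compound 3 to compound 4 (1.32 log units; beyond the scatter)). The numbers for 2-chlorophenyl and 3-fluorophenyl cannot be told apart (a 1.6-fold lower number from compound 2 to compound 4 (0.20 log units; within the scatter)), even though these two groups differ in their halogen and in where it sits, so with three halogenated phenyl groups now in hand, each gives a clearly lower number than 1-phenylethyl. Nothing given here explains why these numbers differ.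

A plain phenyl group with no halogen, or a 2-fluorophenyl or 2-methoxyphenyl group, would show whether a halogen is needed at all and whether the trend from bromo to chloro carries on. A benzyl group would separate the effect of the extra methyl of 1-phenylethyl from that of the carbon that sets its phenyl ring apart from the ring nitrogen.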